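Swapping the Thiophene Attachment Point on a Shared Core

The source may hold more compounds than are shown below. What is called first, only, known or untested is meant among the compounds shown, and "the series" means these compounds.

Compound 1 `Clc1ccc(-c2cc(-c3ccc(Cl)o3)cc(-c3cccs3)n2)cc1`: in a functional assay on DU-145 cells (Homo sapiens) for cytotoxicity, in the presence of a further agent that is not named here (on this read-out higher numbers stand for weaker inhibition and lower numbers for stronger inhibition), compound 1 gives 19200 nM.
Compound 2 `Clc1ccc(-c2cc(-c3ccsc3)nc(-c3ccco3)c2)o1`: in this assay compound 2 gives 18900 nM.

Compound 2 has the lower of the two numbers in this assay, yet compound 1 sits within the scatter of it, so the two cannot be told apart. Compound 3 `Clc1ccc(-c2cc(-c3ccco3)nc(-c3cccs3)c2)o1` keeps the same atoms as compound 2, joined differently: thiophen-2-yl in place of thiophen-3-yl on an aromatic carbon. Among the measured compounds shown here, no measured pair shows what this change does. Compound 1 also carries thiophen-2-yl and gives 19200 nM, so the step is expected to be a 1.0-fold higher number from compound 2 to compound 3 (0.00 log units; within the scatter), nothing beyond the scatter. Compound 3 is therefore estimated at 19000 nM, between 8000 nM and 45000 nM.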

Compound 3, half-maximal inhibitory concentration: 21800 nM
Compound 3: middle estimate off by 1.1-fold (0.06 log units), on the low side; the measured number falls inside the stated range.
By their numbers in this assay, from the lowest: compounds 2, 1 and 3 (each within the scatter of the next).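

In this assay, thiophen-2-yl in place of thiophen-3-yl next to the ring nitrogen gives a 1.2-fold higher number from compound 2 to compound 3 (0.06 log units; within the scatter) and so leaves the two thiophene attachments indistinguishable at this position. Furan-2-yl in place of 4-chlorophenyl on an aromatic carbon gives a 1.1-fold higher number from compound 1 to compound 3 (0.06 log units; within the scatter) and is equally unresolved, even though these two groups differ more visibly. No measurement here explains either result.

Every group compared at these positions is an aromatic ring. As far as these compounds go, whether an amine or a carboxylic acid there would move the number beyond the scatter remains open.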